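The compounds below may be only part of what the source reports. "The series", "measured", "known", "first", "only" and "open" are said of these compounds alone.

Measured so far:
- compound 1, `COc1ccc(NC(=O)Nc2nc(Sc3c[nH]c4ccccc34)cc(N3CCCCC3)n2)cc1`, gives 13500 nM in a functional assay on A549 cells (Homo sapiens) for inhibition, with a stated time of 72 h; a lower number here means a stronger inhibitor, a higher number a weaker inhibitor
- compound 2, `O=C(Nc1ccccc1)Nc1nc(Sc2c[nH]c3ccccc23)cc(N2CCN(Cc3ccccc3)CC2)n1`, gives > 50000 nM in this assay, a limit of the assay and not a number

Compound 1 carries the only actual number shown; the other result is a limit, (the limit of > 50000 nM in this assay, at which 1 of the 2 values shown sits). Compound 3, `COc1ccc(NC(=O)Nc2nc(Nc3cc(OC)cc(OC)c3)cc(Sc3c[nH]c4ccccc34)n2)cc1`, has not been measured. It differs from compound 1 in one place: (3,5-dimethoxyphenyl)amino in place of piperidin-1-yl on an aromatic carbon. Among the compounds with values here, no step between two measured compounds is available, so the size of this change cannot be read from a comparison of the kind already made. The expected effect in this assay is a moderate gain for compound 3 over compound 1, somewhat beyond the usual scatter, though with wide uncertainty. Compound 3 is estimated at 7000 nM, with a range from 1500 nM to 35000 nM, which is expected to mean a step of a 1.9-fold lower number from compound 1 to compound 3 (0.29 log units; within the scatter).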

Compound 3, half-maximal inhibitory concentration: > 50000 nM
Compound 3: a limit, no number (the forecaster's own chance of this, stated with the estimate: 20%); middle value at least 7.1-fold (0.85 log units) away from the limit.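

Within the data shown here, this is the only measured step at this position, the aromatic carbon next to the ring nitrogen, and in this assay placing (3,5-dimethoxyphenyl)amino there in place of piperidin-1-yl gives an at least 3.7-fold higher number from compound 1 to compound 3 (0.56 log units; beyond the scatter). The choice of group at this position therefore matters: with the rest of compound 1 unchanged, this swap costs activity. Compound 3 gives > 50000 nM, a limit of the assay and not a number, so the full size of the loss stays unknown because of this ceiling: the limit of > 50000 nM in this assay, at which 2 of the 3 values shown sit.

A single step cannot tell whether the aromatic ring, the added hydrogen-bond donor or the two methoxy groups matter most. Plain phenylamino or a small open-chain dimethylamino group here would help separate these, and whether any group at this position improves on compound 1 remains open.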